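A few compounds are considered here, and "the series" means these few. Any claim that something is new, unique, unknown or untested is made for them only; others in the source may bear on it.

Series of aryl sulfone quinoxaline anilines, two members measured so far. Compound 1 `COc1cc(Nc2nc3ccccc3nc2S(=O)(=O)c2ccc(C)cc2)cc(OC)c1` reaches only the limit of a functional assay on HCT-116 cells (Homo sapiens) for cytotoxicity, read by MTT assay, with a stated time of 72 h (on this read-out lower numbers stand for stronger inhibition and higher numbers for weaker inhibition), giving > 50000 nM as a limit and not a number. Compound 2 `COc1ccc(Nc2nc3ccccc3nc2S(=O)(=O)c2ccc(Br)cc2)cc1` gives 3400 nM in this assay, the only actual number shown. The other value, that of compound 1, is a limit (the limit of > 50000 nM in this assay, at which 1 of the 2 values shown sits).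

The step to be followed goes from compound 2 to compound 3 `COc1cc(Nc2nc3ccccc3nc2S(=O)(=O)c2ccc(Br)cc2)cc(OC)c1`: 3,5-dimethoxyphenyl in place of 4-methoxyphenyl on a nitrogen on an aromatic ring. For the measured compounds named here, no measured pair differs in this one place, so the size of the step is not known from a measurement. Compound 3 shares its 3,5-dimethoxyphenyl with compound 1, whose > 50000 nM is a limit, so a large loss in this assay is expected, a 7.4-fold higher number from compound 2 to compound 3 (0.87 log units; beyond the scatter). The estimate for compound 3 is therefore 25000 nM, with a range from 6000 nM to 100000 nM, and a fair chance that only a limit is reported.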

Compound 3, half-maximal inhibitory concentration: > 50000 nM
Compound 3 ended at the assay's limit; the forecaster's own chance of this, stated with the estimate: 45%; middle value at least 2.0-fold (0.30 log units) away from the limit.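

For the compounds shown here, with bromo held constant, 3,5-dimethoxyphenyl in place of 4-methoxyphenyl on the nitrogen gives in this assay an at least 14-fold higher number from compound 2 to compound 3 (1.16 log units; beyond the scatter), the first measured step at this place. The 3,5-dimethoxyphenyl group therefore goes with a large loss in the bromo compounds too, and the limit reached by compound 1 is not tied to its methyl group. Bromo in place of methyl on the aromatic carbon cannot be read between the two compounds that carry 3,5-dimethoxyphenyl, as both values are limits: the limit of > 50000 nM in this assay, at which 2 of the 3 values shown sit.

The compounds shown do not separate the effect of the second methoxy group from the effect of where the methoxy groups sit. Also open, from the compounds shown here alone, is how an unsubstituted phenyl, or a phenyl carrying an amine, on the nitrogen would read in this assay.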